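Adding a bromo group to compound 1

The source may report more compounds than this note shows. Statements on the series, on what has been measured and on what is new or still open speak of the compounds shown alone.

Measured in a functional assay on A549 cells (Homo sapiens) for inhibition, read by MTT assay, with a stated time of 24 h; on this read-out higher numbers stand for weaker inhibition of growth and lower numbers for stronger inhibition of growth:
Compound 1 `COc1ccccc1C(=O)n1c(-c2cn(C)c3ccccc23)nc2ccccc21` gives 12300 nM
Compound 2 `COc1cccc(C(=O)n2c(-c3cn(C)c4ccccc34)nc3ccccc32)c1` gives 10200 nM
Compound 3 `Cn1cc(-c2nc3ccccc3n2C(=O)c2cccc(Br)c2)c2ccccc21` gives 34200 nM

Compound 1 belongs to the lower pair of these three numbers. Its nearest neighbour lies within the scatter, a 1.2-fold lower number from compound 1 to compound 2 (0.08 log units; within the scatter), while the furthest lies clearly apart, a 2.8-fold higher number from compound 1 to compound 3 (0.44 log units; beyond the scatter).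

The next compound, compound 4 `COc1ccccc1C(=O)n1c(-c2cn(C)c3ccc(Br)cc23)nc2ccccc21`, differs from compound 1 in one place: bromo in place of hydrogen on an aromatic carbon. This is bromo in place of hydrogen on an aromatic carbon, in a six-membered aromatic ring of carbon only that is part of a fused or bridged system of two rings.

Among the measured compounds shown here, no measured step makes this exact change. The closest is bromo in place of methoxy on an aromatic carbon, a 3.4-fold higher number from compound 2 to compound 3 (0.53 log units; beyond the scatter), a modest step. However, it replaces methoxy rather than hydrogen, and it does so on the phenyl attached to the carbonyl carbon. It therefore offers only a weak hint of a higher number. In this assay, no step beyond the scatter is expected, with a slight lean upward. The expected change is a 1.1-fold higher number from compound 1 to compound 4 (0.06 log units; within the scatter). For compound 4, the estimated value is 14000 nM, with an expected range from 5000 nM to 40000 nM.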

Compound 4, concentration for 50% growth inhibition: 12800 nM
Compound 4: middle estimate off by 1.1-fold (0.04 log units), on the high side; the measured number falls inside the stated range.
By their numbers in this assay, from the lowest: compounds 2, 1 and 4 (each within the scatter of the next); then compound 3.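

In this assay, among the compounds shown here, the step to compound 4 gives the first reading of a change on the six-membered aromatic ring of carbon only in the fused system of two rings: a 1.0-fold higher number from compound 1 to compound 4 (0.02 log units; within the scatter). The earlier compounds shown here varied only the phenyl on the carbonyl carbon, where a bromo did go with a change beyond the scatter, a 3.4-fold higher number from compound 2 to compound 3 (0.53 log units; beyond the scatter), although that step replaced methoxy rather than hydrogen. Compound 4 shows that a higher number does not follow from a bromo as such, since at this position a single bromine atom in place of hydrogen leaves the growth-inhibition read-out within the scatter, and no supporting data bear on why this is so.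

What the compounds shown leave open is whether this position stays just as indifferent to a group of another kind, such as an amine, a carboxylic acid or a longer alkyl chain. They also leave open whether the same bromo would behave alike with the 3-methoxyphenyl or 3-bromophenyl on the carbonyl carbon, as this single step rests on the 2-methoxyphenyl of compound 1 alone.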